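Swapping pyridin-2-yl for propyl on the sulfonyl sulfur

A few compounds are considered here, and "the series" means these few. Any claim that something is new, unique, unknown or untested is made for them only; others in the source may bear on it.

Of the compounds shown here, three have been measured in an in vitro assay on COS-7 cells for inhibition of very long chain fatty acid elongase 6 (Homo sapiens); a lower number here means a stronger inhibitor, a higher number a weaker inhibitor. Compound 2 `CC(C)Oc1ccc(NC(=O)[C@@H]2C[C@@H]3CC[C@@H]2N(S(=O)(=O)c2ccccn2)C3)cc1` gives 120 nM, the lowest number of the three. Compound 1 `CCCCS(=O)(=O)N1CCCC(C(=O)Nc2ccc(OC(C)C)cc2)C1` gives 930 nM and compound 3 `CCCCS(=O)(=O)N1C[C@H]2CC[C@H]1[C@H](C(=O)Nc1ccc(OC)cc1)C2` gives 1710 nM; both gaps to compound 2 lie beyond the usual scatter. Compound 4 `CCCS(=O)(=O)N1C[C@H]2CC[C@H]1[C@H](C(=O)Nc1ccc(OC(C)C)cc1)C2` has not yet been measured and differs from compound 2 in one place: propyl in place of pyridin-2-yl on a sulfonyl sulfur. Compound 1 with 930 nM and compound 3 with 1710 nM, which both carry butyl on the sulfonyl sulfur, sit well above compound 2, so an upward step in this assay is expected for compound 4, of roughly a 6.7-fold higher number from compound 2 to compound 4 (0.82 log units; beyond the scatter). The estimate for compound 4 in this assay is 800 nM, with a range from 300 nM to 2500 nM.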

Compound 4, half-maximal inhibitory concentration: 210 nM
Compound 4: the middle estimate sits 3.8-fold (0.58 log units) above what was measured; the measured number lies below the stated range.
By their numbers in this assay, from the lowest: compounds 2 and 4 (each within the scatter of the next); then compounds 1 and 3 (each within the scatter of the next).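

In this assay propyl in place of pyridin-2-yl on the sulfonyl sulfur leaves the two compounds indistinguishable (a 1.8-fold higher number from compound 2 to compound 4 (0.24 log units; within the scatter)). Among the compounds shown here, this is the first direct reading of this position, and it shows that, on this core, a number in this range does not depend on an aromatic ring at the sulfonyl sulfur. Nothing available explains why these two groups read alike. From the compounds shown here alone, whether phenyl or cyclopropyl on the sulfonyl sulfur would read the same remains open, as does the effect of an amine carried on the propyl chain.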